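This account rests on a few compounds, and the source may have more. Where it says the series, first, only, none or still open, it means among the compounds named here.

Three compounds share one amide chain that ends in the same halogenated benzyl group and differ only in the small aromatic ring sitting on a saturated chain carbon, two bonds along the chain from a carbonyl carbon. Compound 1 `Cc1c[nH]nc1CCC(=O)NCc1ccc(F)cc1Cl` carries a 4-methyl-1H-pyrazol-3-yl group, and in a functional assay for antagonist activity at P2X purinoceptor 7 (Homo sapiens) (on this read-out lower numbers stand for stronger inhibition and higher numbers for weaker inhibition), compound 1 gives 398 nM. Compound 2 `Cc1cnn(C)c1CCC(=O)NCc1ccc(F)cc1Cl` carries a 1,4-dimethyl-1H-pyrazol-5-yl group; in this assay compound 2 gives 158 nM, which is a 2.5-fold lower number from compound 1 to compound 2 (0.40 log units; beyond the scatter). Compound 3 `Cc1cc(CCC(=O)NCc2ccc(F)cc2Cl)n(C)n1` carries a 1,3-dimethyl-1H-pyrazol-5-yl group, and in this assay compound 3 gives 316 nM. That number cannot be told apart from its neighbours: the change is a 1.3-fold lower number from compound 1 to compound 3 (0.10 log units; within the scatter) and a 2.0-fold higher number from compound 2 to compound 3 (0.30 log units; within the scatter).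

Compound 4 `Cc1noc(C)c1CCC(=O)NCc1ccc(F)cc1Cl` is not yet measured. It differs from compound 3 by 3,5-dimethyl-1,2-oxazol-4-yl in place of 1,3-dimethyl-1H-pyrazol-5-yl on a saturated chain carbon, two bonds along the chain from a carbonyl carbon. Going by the values given here, no measured step swaps a pyrazole for a 1,2-oxazole, so none bears directly on this change. The three steps that do exist all rework this same ring, and even the largest of them, from compound 1 to compound 2, was only modest, while the other two stayed within the scatter. A step of similar size, with no clear direction, is therefore expected, amounting to a 1.1-fold higher number from compound 3 to compound 4 (0.04 log units; within the scatter). Compound 4 is estimated at 350 nM, in a range from 120 nM to 1000 nM.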

Compound 4, half-maximal inhibitory concentration: 63.1 nM
Compound 4: middle estimate off by 5.5-fold (0.74 log units), on the high side, outside the stated range (below it).
By their numbers in this assay, from the lowest: compound 4; then compounds 2, 3 and 1 (each within the scatter of the next, the first and the last beyond it).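

This position tolerates more change than the pyrazole swaps suggested: the 3,5-dimethyl-1,2-oxazol-4-yl group gives a 5.0-fold lower number from compound 3 to compound 4 (0.70 log units; beyond the scatter), a 2.5-fold lower number from compound 2 to compound 4 (0.40 log units; beyond the scatter) and a 6.3-fold lower number from compound 1 to compound 4 (0.80 log units; beyond the scatter) in this assay, so compound 4 stands beyond the scatter of every other compound here, with the lowest number. The gain does not follow the simple counts, since the leaving 1,3-dimethyl-1H-pyrazol-5-yl group and the entering group match in heavy atoms, ring size, hydrogen-bond donors and hydrogen-bond acceptors; what differs is that one ring nitrogen gives way to an oxygen and that the ring is attached through a different ring position. Nothing available here accounts for why this ring gives the lower number.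

The change alters the ring atoms and the attachment together, so a 3,5-dimethyl-1H-pyrazol-4-yl group would be needed to tell whether the oxygen or the attachment carries the gain. Also open, as far as these compounds go, is whether the two methyl groups matter, which an unsubstituted 1,2-oxazol-4-yl group would test, and whether the gain survives a longer chain between this ring and the carbonyl.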